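Chloro in place of fluoro on compound 2

The compounds below may be only part of what the source reports. "The series", "measured", "known", "first", "only" and "open" are said of these compounds alone.

compound 1 `CCNc1n[n+]([O-])c2cc(F)ccc2[n+]1[O-]` gives 4.6 ug/mL
compound 2 `[O-][n+]1nc(NC2CC2)[n+]([O-])c2ccc(F)cc21` gives 1.3 ug/mL
compound 3 `[O-][n+]1nc(N[C@@H]2C[C@H]3CC[C@@H]2C3)[n+]([O-])c2ccc(F)cc21` gives < 2.5 ug/mL (a limit, not a number)

In an ADME assay on Vero cells (Chlorocebus sabaeus) for cytotoxicity, read by CellTiter-Glo, with a stated time of 72 h (a lower number here means that less compound is tolerated, a higher number that more compound is tolerated), compound 2 has the lower of the two exact numbers, and the gap to compound 1 is beyond the scatter (a 3.5-fold lower number from compound 1 to compound 2 (0.55 log units; beyond the scatter)). The third value is only a limit (the comparison shows a step that the limit leaves unreadable from compound 2 to compound 3).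

Compound 4 `[O-][n+]1nc(NC2CC2)[n+]([O-])c2ccc(Cl)cc21` keeps the cyclopropyl group of compound 2 and differs only by chloro in place of fluoro on an aromatic carbon. The measured steps (a 3.5-fold lower number from compound 1 to compound 2 (0.55 log units; beyond the scatter)) and (an at least 1.8-fold lower number from compound 1 to compound 3 (0.26 log units; that floor lies within the scatter)) both change the group on the nitrogen and leave the fluoro untouched, so neither speaks directly to this swap. With no measured swap of this kind to go on, the expected step stays within the scatter (a 1.1-fold lower number from compound 2 to compound 4 (0.03 log units; within the scatter)). The estimate for compound 4 is 1.2 ug/mL (expected range from 0.4 ug/mL to 3.5 ug/mL).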

Compound 4, half-maximal cytotoxic concentration: 1.3 ug/mL
The estimate for compound 4 lay 1.1-fold (0.03 log units) below the measured number, within the range that was stated.
By their numbers in this assay, from the lowest: compounds 2 and 4 (each within the scatter of the next); then compound 1.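

In this assay, putting chloro in place of fluoro on this aromatic carbon gives no change at the digits printed from compound 2 to compound 4 (within the scatter), so with the cyclopropyl group held fixed, compound 2 and compound 4 cannot be told apart. The earlier compounds shown here differ only in the group on the nitrogen, and none of them tests the halogen; this pair shows that, on this core with this nitrogen group, fluoro and chloro are interchangeable at this position as far as this read-out goes. Nothing measured here explains why the two compounds read alike.

On these data alone, only these two halogens at this one position are compared, so it remains open whether a methoxy group or an amine on the same carbon would also leave the number within the scatter. As far as these compounds go, whether the same swap would read alike with the ethyl group of compound 1 also remains open.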